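A few compounds are considered here, and "the series" means these few. Any claim that something is new, unique, unknown or untested is made for them only; others in the source may bear on it.

In an assay on membranes from cerebellum (strain Wistar) for inhibition of Monoglyceride lipase (Rattus norvegicus), read by HPLC, tested at 100 uM (a lower number here means less inhibition, a higher number more inhibition at the concentration tested (going by the name of the read-out)), compound 1 `CC1(C)COC(c2cccc(OC(=O)NC3CCCCC3)c2)=N1` gives 20%, while compound 2 `C[C@@H]1COC(c2cccc(OC(=O)NC3CCCCC3)c2)=N1` gives 16%. Compound 2 thus holds the lower of the two numbers, yet the step of a number 4 percentage points lower from compound 1 to compound 2 (within the scatter) lies within the scatter. Compound 3 `COC(=O)[C@@H]1COC(c2cccc(OC(=O)NC3CCCCC3)c2)=N1` differs from compound 2 by methoxycarbonyl in place of methyl on a saturated ring carbon. Going by the values given here, the only measured step, a number 4 percentage points lower from compound 1 to compound 2 (within the scatter), also alters this five-membered non-aromatic ring and stayed within the scatter, so no change beyond the scatter is expected here. The expected step is a number 2 percentage points higher from compound 2 to compound 3 (within the scatter). Compound 3 is therefore estimated at 18%, between 5% and 35%.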

Compound 3, a percentage reported as inhibition, at one concentration (the size of the read-out at that concentration, not a potency): 25%
Estimate against measurement, compound 3: 7 percentage points below, within the range that was stated.
By their numbers in this assay, from the lowest: compounds 2, 1 and 3 (each within the scatter of the next).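

In this assay, methoxycarbonyl in place of methyl on the saturated ring carbon next to the ring nitrogen gives a number 9 percentage points higher from compound 2 to compound 3 (within the scatter), so even this larger ester group, with its hydrogen-bond acceptors, produces no change beyond the scatter. The earlier pair, which differed only by a methyl group, could not show this. No measurement given here explains the result.

From the compounds shown here alone, whether an amine or a carboxylic acid on this ring carbon would move the number beyond the scatter remains open.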